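This account rests on a few compounds, and the source may have more. Where it says the series, first, only, none or still open, it means among the compounds named here.

Measured compounds in an assay on CHO cells for antagonist activity at transient receptor potential cation channel subfamily V member 1 (Homo sapiens), read by scintillation counting, with a stated time of 5 min, in the presence of a further agent that is not named here; on this read-out higher numbers stand for an effect only at larger amounts of compound and lower numbers for an effect already at smaller amounts:
compound 1 `CN(C)C1(Cc2ccccc2)CCN(c2cc(C(F)(F)F)ccc2CNC(=O)Nc2ccc(CNS(C)(=O)=O)c(F)c2)CC1` gives 25 nM
compound 2 `CN(C)C1(Cc2ccccc2)CCN(c2cc(C(F)(F)F)ccc2CNC(=O)Nc2ccc(CO)c(F)c2)CC1` gives 81 nM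
compound 3 `CN(C)C1(Cc2ccccc2)CCN(c2cc(C(F)(F)F)ccc2CNC(=O)Nc2cccc3ccc(O)cc23)CC1` gives 8.9 nM

Compound 3 stands lowest of the three numbers in this assay; compound 1 is nearest to it and compound 2 furthest, as their values show.

Compound 4 `CN(C)C1(Cc2ccccc2)CCN(c2cc(C(F)(F)F)ccc2CNC(=O)Nc2cccc3c2CC(O)CC3)CC1` differs from compound 3 in one place: 3-hydroxy-1,2,3,4-tetrahydronaphthalen-5-yl in place of 7-hydroxynaphthalen-1-yl on an amide-type nitrogen. Of the measured steps, only a 9.1-fold lower number from compound 2 to compound 3 (0.96 log units; beyond the scatter) touches the group on that amide-type nitrogen, and it swaps the whole group, so it does not isolate the loss of one aromatic ring and the shift of the hydroxy within the bicycle. The step of a 3.2-fold higher number from compound 1 to compound 2 (0.51 log units; beyond the scatter) concerns a chain on a different part of the molecule and does not bear on this change. For the measured compounds named here, with no direct precedent, the expected step from compound 3 to compound 4 in this assay is small, a 2.2-fold higher number from compound 3 to compound 4 (0.35 log units; beyond the scatter), a slight rise in number or none beyond the scatter. Compound 4 is therefore estimated at 20 nM, in the range 6 nM to 70 nM.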

Compound 4, half-maximal effective concentration: 10.1 nM
Estimate against measurement, compound 4: 2.0-fold (0.30 log units) above, and the stated range covers the measured number.
By their numbers in this assay, from the lowest: compounds 3 and 4 (each within the scatter of the next); then compound 1; then compound 2.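

In this assay, the group on the amide-type nitrogen can lose aromaticity in one of its two rings without a readable change, a 1.1-fold higher number from compound 3 to compound 4 (0.05 log units; within the scatter). A second aromatic ring in this group is therefore not needed to hold the number at this level, at least for this pair. The 3-hydroxy-1,2,3,4-tetrahydronaphthalen-5-yl group also keeps the difference from the 3-fluoro-4-(hydroxymethyl)phenyl group, an 8.0-fold lower number from compound 2 to compound 4 (0.90 log units; beyond the scatter), and no measurement available here accounts for either step.

Going by these compounds, both bicyclic groups carry a hydroxy, so the contribution of that hydroxy remains open, including what a methoxy, an amine or a carboxylic acid would give in its place. Also open, on these data alone, is whether a longer chain, such as hydroxyethyl, would be accepted on the non-aromatic ring.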